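Sulfonyl for carbonyl on the ring nitrogen of compound 2

A few compounds are considered here, and "the series" means these few. Any claim that something is new, unique, unknown or untested is made for them only; others in the source may bear on it.

Of the compounds shown here, two have been measured in a functional assay on MDA-MB-231 cells (Homo sapiens) for inhibition, read by sulforhodamine B assay, tested at 10 uM; a higher number here means more inhibition at the concentration tested (going by the name of the read-out), a lower number less inhibition. Compound 1 `CN1CCN(c2ccc(C3=NN(C(=O)c4ccc(F)cc4)C(c4ccc(N(C)C)cc4)C3)cc2)CC1` gives 3.5% in this assay. Compound 2 `CN(C)c1ccc(C2CC(c3ccc(-n4ccnc4)cc3)=NN2C(=O)c2ccc(F)cc2)cc1` gives 9.4% in this assay; compound 2 stands alongside compound 1, the two values lying within the usual scatter of each other, as the step of a number 5.9 percentage points higher from compound 1 to compound 2 (within the scatter) shows. Compound 3 `CN(C)c1ccc(C2CC(c3ccc(-n4ccnc4)cc3)=NN2S(=O)(=O)c2ccc([N+](=O)[O-])cc2)cc1` is not yet measured. It differs from compound 2 as follows: (4-nitrophenyl)sulfonyl in place of (4-fluorophenyl)carbonyl on an amine nitrogen in a ring. Going by the values given here, the only measured step alters a group on an aromatic carbon, not the amine nitrogen in the ring, so no measured step bears on this change; the data give no guide to its direction. Compound 3 is therefore expected to sit near compound 2, with the step of a number 2.6 percentage points higher from compound 2 to compound 3 (within the scatter) estimated as no more than the scatter allows. For compound 3 the estimate in this assay is 12%, expected to fall between 0% and 35%.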

Compound 3, a percentage reported as inhibition, at one concentration (the size of the read-out at that concentration, not a potency): 41.5%
Estimate against measurement, compound 3: 29.5 percentage points below; the whole stated range lies below it.
By their numbers in this assay, from the lowest: compounds 1 and 2 (each within the scatter of the next); then compound 3.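

The amine nitrogen in the five-membered non-aromatic ring turns out to be a place where the read-out in this assay can move well past the scatter: (4-nitrophenyl)sulfonyl in place of (4-fluorophenyl)carbonyl gives a number 32.1 percentage points higher from compound 2 to compound 3 (beyond the scatter) on the otherwise unchanged core. The only earlier step, on an aromatic carbon, stayed within the scatter, so this is the first change among the compounds shown that clearly separates two of them. Nothing available on these compounds accounts for the rise.

This single step swaps the carbonyl for a sulfonyl and the 4-fluorophenyl for a 4-nitrophenyl together, so the compounds shown cannot say which of the two carries it. Going by these compounds, a (4-fluorophenyl)sulfonyl group or a (4-nitrophenyl)carbonyl group on the same nitrogen would separate the two, and an amine in place of the nitro group remains open as well.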